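This account rests on a few compounds, and the source may have more. Where it says the series, first, only, none or still open, it means among the compounds named here.

Measured so far:
- Compound 1, `CC(C)(C)c1ccc(CNC(=O)NCCCCl)cc1`: 17000 nM
- Compound 2, `CCCCC(O)c1cccc(NC(=O)NC(=O)CCl)c1`: 5700 nM

In a functional assay on MCF7 cells (Homo sapiens) for antiproliferative activity, with a stated time of 48 h (on this read-out lower numbers stand for stronger inhibition and higher numbers for weaker inhibition), compound 1 stands at the higher of the two numbers, that is, it is the weaker inhibitor of the pair; compound 2 lies a good deal lower, and that gap is beyond the usual scatter. Compound 3, `CC(C)(C)c1ccc(CNC(=O)CCCl)cc1`, has not yet been tested. It differs from compound 1 in one place: 2-chloroethyl in place of (3-chloropropyl)amino on a carbonyl carbon. Among the measured compounds shown here, no measured pair of compounds shows this particular change, so its effect can only be expected, not read off. The expectation is a modest step toward stronger inhibition in this assay, somewhat larger than the scatter but not dramatic; the step from compound 1 to compound 3 is estimated as a 2.1-fold lower number from compound 1 to compound 3 (0.33 log units; beyond the scatter). Compound 3 is therefore expected to give about 8000 nM in this assay, within a range from 2000 nM to 30000 nM.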

Compound 3, half-maximal inhibitory concentration: 67000 nM
Estimate against measurement, compound 3: 8.4-fold (0.92 log units) below, and the stated range ends below it.
By their numbers in this assay, from the lowest: compound 2; then compound 1; then compound 3.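

In this assay, putting 2-chloroethyl in place of (3-chloropropyl)amino on a carbonyl carbon gives a 3.9-fold higher number from compound 1 to compound 3 (0.60 log units; beyond the scatter) and so moves toward weaker inhibition. Among the compounds shown here, this is the first direct reading at this position, as compounds 1 and 2 differ in more than one place, and it shows that the position responds to this change and that the group in compound 1 is the better of the two here. Nothing available explains why the number rises.

The change removes the nitrogen with its hydrogen-bond donor and also shortens the group, so the compounds shown cannot separate these two differences. A 3-chloropropyl group or a (2-chloroethyl)amino group on the same carbonyl carbon would pull them apart, and a propylamino group would address the role of the chlorine.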